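This account rests on a few compounds, and the source may have more. Where it says the series, first, only, none or still open, it means among the compounds named here.

In an ADME assay on microsomes from liver (Homo sapiens) for metabolic stability, read by LC-MS, with a stated time of 60 min, tested at 500 uM (on this read-out higher numbers stand for a more stable compound and lower numbers for a less stable compound), compound 1 (`COc1cc2c(cc1OC)CN(c1ccc(C=O)cc1)CC2`) stands at 9.2% while compound 2 (`COc1cc2c(cc1OC)CN(c1cccnc1)CC2`) stands at 15.5% and compound 3 (`COc1cc2c(cc1OC)CN(c1ccccn1)CC2`) stands at 17.7% with all three values within the scatter of one another. Compound 3 is therefore not separated from either of the other two. Compound 4 (`COc1cc2c(cc1OC)CN(c1ccc(F)cc1)CC2`) differs from compound 3 as follows (4-fluorophenyl in place of pyridin-2-yl on an amine nitrogen in a ring) and so carries 4-fluorophenyl in place of pyridin-2-yl on an amine nitrogen in a ring. Among the measured compounds shown here, the only measured step at that place is a number 2.2 percentage points higher from compound 2 to compound 3 (within the scatter) and it swaps one pyridinyl group for another, so it bears only loosely on an aromatic ring of carbon only. For the measured compounds named here, compound 1 is the sole measured member with such a ring, and its 9.2% lies within the scatter of compound 3. No step beyond the scatter is expected in this assay and any shift is expected to be downward. The expected change is a number 5.7 percentage points lower from compound 3 to compound 4 (within the scatter) on this basis. Compound 4 is estimated at 12% with an expected range from 4% to 24% for now.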

Compound 4, percent of the compound remaining: 56.9%
Estimate against measurement, compound 4: 44.9 percentage points below; measured number above the stated range.
By their numbers in this assay, from the lowest: compounds 1, 2 and 3 (each within the scatter of the next); then compound 4.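

In this assay, the group on the amine nitrogen in a ring can move the number well beyond the scatter: 4-fluorophenyl in place of pyridin-2-yl gives a number 39.2 percentage points higher from compound 3 to compound 4 (beyond the scatter), and 4-fluorophenyl in place of pyridin-3-yl gives a number 41.4 percentage points higher from compound 2 to compound 4 (beyond the scatter), whereas the exchange between the two pyridinyl groups gave only a number 2.2 percentage points higher from compound 2 to compound 3 (within the scatter). An aromatic ring of carbon only does not by itself fix the number, as fluoro in place of formyl on an aromatic carbon gives a number 47.7 percentage points higher from compound 1 to compound 4 (beyond the scatter). No evidence at hand explains these steps.

From the compounds shown here alone, whether the high number belongs to fluoro or to the ring of carbon only remains open; unsubstituted phenyl, or chloro, methoxy or nitrile on the aromatic carbon, would separate the two. Also open, going by these compounds, is whether a pyridinyl group carrying fluoro would behave like 4-fluorophenyl.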